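Aryl triazole series: from 2-acetylphenyl to 4-chlorophenyl

The compounds below may be only part of what the source reports. "The series", "measured", "known", "first", "only" and "open" are said of these compounds alone.

compound 1 `C=C1CCC[C@]2(C)CCC(c3cn(-c4ccc(C(C)=O)cc4)nn3)=CC[C@@]12C`: 51700 nM
compound 2 `C=C1CCC[C@]2(C)CCC(c3cn(-c4ccc(I)cc4)nn3)=CC[C@@]12C`: 145000 nM
compound 3 `C=C1CCC[C@]2(C)CCC(c3cn(-c4ccccc4C(C)=O)nn3)=CC[C@@]12C`: 48500 nM

All three values come from a functional assay on DU-145 cells (Homo sapiens) for cytotoxicity, read by MTT assay, with a stated time of 48 h; on this read-out lower numbers stand for stronger inhibition and higher numbers for weaker inhibition. Compound 3, at 48500 nM, cannot be separated from compound 1, and the two form a pair apart from compound 2: a 3.0-fold lower number from compound 2 to compound 3 (0.48 log units; beyond the scatter).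

The next compound is compound 4 `C=C1CCC[C@]2(C)CCC(c3cn(-c4ccc(Cl)cc4)nn3)=CC[C@@]12C`, with 4-chlorophenyl in place of 2-acetylphenyl on an aromatic nitrogen. For the measured compounds named here, no chlorine-bearing compound has been measured yet, so the evidence is indirect. Moving the acetyl group gave a 1.1-fold lower number from compound 1 to compound 3 (0.03 log units; within the scatter), so compound 1 can stand in for compound 3 as a starting point. Going by the values given here, replacing acetyl with iodo gave a 2.8-fold higher number from compound 1 to compound 2 (0.45 log units; beyond the scatter), and compound 2 is the only measured compound without an acetyl group. Three compounds are a thin basis, and chlorine need not follow iodo. Even so, a modest rise in the number is the most likely outcome in this assay, probably no larger than the iodo step. The expected move is a 2.1-fold higher number from compound 3 to compound 4 (0.31 log units; beyond the scatter), though a result within the scatter would not be surprising. The estimate for compound 4 is 100000 nM, with an expected range of 45000 nM to 200000 nM.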

Compound 4, half-maximal inhibitory concentration: 26000 nM
The estimate for compound 4 lay 3.8-fold (0.59 log units) above the measured number; measured number below the stated range.
By their numbers in this assay, from the lowest: compounds 4, 3 and 1 (each within the scatter of the next); then compound 2.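

In this assay, an acetyl group proves unnecessary for staying in the range of the acetyl compounds: 4-chlorophenyl gives a 1.9-fold lower number from compound 3 to compound 4 (0.27 log units; within the scatter) and a 2.0-fold lower number from compound 1 to compound 4 (0.30 log units; within the scatter), so compound 4 cannot be separated from either one. The earlier link between losing acetyl and a higher number therefore rested on compound 2 alone, and the exchange of one halogen for the other on the same aromatic carbon now gives a 5.6-fold lower number from compound 2 to compound 4 (0.75 log units; beyond the scatter), so compound 2 stands apart from the other three and the two halogens cannot be treated as one class at this place. No measurement is available that accounts for the difference between the chloro and iodo compounds.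

Going by these compounds, it remains open whether bromo or fluoro on that aromatic carbon would group with compound 4 or with compound 2, and whether an amine or a carboxylic acid there would leave the number within the range of compounds 1, 3 and 4. All four compounds share one core and differ only in the aryl group on the aromatic nitrogen, so they give no reading on any change to the core itself.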